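A few compounds are considered here, and "the series" means these few. Any claim that something is new, unique, unknown or untested is made for them only; others in the source may bear on it.

Compounds measured so far:

- Compound 1 `CCCCCCCCCCCCCCCCCC[C@@H](N)[C@@H](O)CO`: 3500 nM
- Compound 2 `CCCCCCCCCCCCCC[C@H](NC(=O)OC(C)(C)C)[C@H](O)CO`: 23800 nM
- Compound 3 `CCCCCCCCCCCCCC[C@@H](N)[C@@H](O)CO`: 2490 nM

In a functional assay on UMSCC22B cells (Homo sapiens) for inhibition (on this read-out lower numbers stand for stronger inhibition and higher numbers for weaker inhibition), compound 1 stands second highest of the three numbers. Its nearest neighbour is compound 3, with the step of a 1.4-fold lower number from compound 1 to compound 3 (0.15 log units; within the scatter); its furthest is compound 2, which gives 23800 nM, a gap well beyond the scatter. The step from compound 1 to compound 3 is a shortening of the chain and is within the scatter.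

Compound 4 `CCCCCCCCCCCCCCCCCC[C@H](N)[C@H](O)CO` differs from compound 1 as follows: the two compounds have the same atoms and bonds and differ only in configuration as drawn: 2 of 2 stereo elements differ (all stereocentres are inverted: mirror images); a stereocentre at a saturated chain carbon is drawn R in compound 1 and S in compound 4; a stereocentre at a saturated chain carbon is drawn R in compound 1 and S in compound 4. For the measured compounds named here, none of the measured steps concerns configuration: the only single-change step, from compound 1 to compound 3, alters the chain, and compound 2 differs in both the chain and the amine substituent. There is therefore no measured basis for the size or direction of the step in this assay from compound 1 to compound 4, and the expectation rests on the value of compound 1 alone, with a wide range. Compound 4 is expected to give 5000 nM, between 1500 nM and 20000 nM, which would mean an expected step of a 1.4-fold higher number from compound 1 to compound 4 (0.15 log units; within the scatter).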

Compound 4, half-maximal inhibitory concentration: 2340 nM
Estimate against measurement, compound 4: 2.1-fold (0.33 log units) above, and the stated range covers the measured number.
By their numbers in this assay, from the lowest: compounds 4, 3 and 1 (each within the scatter of the next); then compound 2.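

Inverting both stereocentres in this assay gives a 1.5-fold lower number from compound 1 to compound 4 (0.17 log units; within the scatter) and so leaves the number within the scatter. For the compounds shown here, the earlier compounds altered the chain, or the chain together with the amine substituent, so this is the first reading on configuration at these two saturated chain carbons, and here the read-out does not separate the mirror images: the fact that compounds 1 and 4 differ only in the configuration as drawn. That finding rests on this single pair and holds for the longer chain only.

The compounds shown leave open whether inverting just one of the two stereocentres would also stay within the scatter, or whether the mirror image of compound 3 would behave like compound 4. They also leave open how this assay would read a compound carrying a phosphate ester or an acetamide.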